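A few compounds are considered here, and "the series" means these few. Any claim that something is new, unique, unknown or untested is made for them only; others in the source may bear on it.

Two compounds share one core. Compound 1 `CC1(C)Cc2c(sc(NC(=O)c3ccccc3O)c2C(N)=O)CO1` in an assay on cells for positive allosteric modulation of Cystic fibrosis transmembrane conductance regulator variant G551D (Homo sapiens), with stated times of 10 min and 2 min, in the presence of a further agent that is not named here (on this read-out higher numbers stand for an effect only at larger amounts of compound and lower numbers for an effect already at smaller amounts), gives 490 nM. Compound 2 `CC1(C)Cc2c(sc(NC(=O)[C@@H](O)C(C)(C)C)c2C(N)=O)C(C)(C)O1` in this assay gives 421 nM, a number within the scatter of that of compound 1, so the two cannot be ordered. Compound 3 `Cc1cn[nH]c1C(=O)Nc1sc2c(c1C(N)=O)CC(C)(C)OC2(C)C` differs from compound 2 by 4-methyl-1H-pyrazol-5-yl in place of 1-hydroxy-2,2-dimethylpropyl on a carbonyl carbon. For the measured compounds named here, no measured pair shows this change, so the shift is expected to be a 1.1-fold lower number from compound 2 to compound 3 (0.02 log units; within the scatter), none beyond the scatter in either direction. Compound 3 is therefore estimated at 400 nM, within a range from 150 nM to 1200 nM.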

Compound 3, half-maximal effective concentration: 123 nM
The estimate for compound 3 lay 3.3-fold (0.51 log units) above the measured number, and the stated range ends above it.
By their numbers in this assay, from the lowest: compound 3; then compounds 2 and 1 (each within the scatter of the next).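

At the carbonyl carbon whose other neighbour is the amide-type nitrogen, the group present does matter in this assay: 4-methyl-1H-pyrazol-5-yl in place of 1-hydroxy-2,2-dimethylpropyl gives a 3.4-fold lower number from compound 2 to compound 3 (0.53 log units; beyond the scatter). The two groups have the same counts of heavy atoms, hydrogen-bond donors and hydrogen-bond acceptors, so these counts alone do not set the number in this pair. Nothing measured here gives a reason for this step.

The compounds shown leave open whether the methyl group on the ring contributes to the step. They also leave open whether a plain 1H-pyrazol-5-yl or a furan ring on the same carbonyl carbon would give a similar number.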